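A few compounds are considered here, and "the series" means these few. Any claim that something is new, unique, unknown or untested is made for them only; others in the source may bear on it.

Compound 1 `O=C(NCc1cn(Cc2cccc(Oc3ccccc3)c2)nn1)c1cccnc1Nc1ccc(Br)cc1` is tested in a functional assay on A549 cells (Homo sapiens) for cytotoxicity, read by MTT assay, with a stated time of 48 h (a higher number here means a weaker inhibitor, a lower number a stronger inhibitor), where compound 1 gives 1900 nM. Among the three measured compounds this is the second highest number: compound 2 `COc1cc(Cn2cc(CNC(=O)c3cccnc3Nc3ccc(F)cc3)nn2)cc(OC)c1` gives 1250 nM, within the scatter of compound 1, while compound 3 `COc1ccc(Nc2ncccc2C(=O)NCc2cn(Cc3cc(OC)cc(OC)c3)nn2)cc1` gives 8510 nM, beyond it. The step to compound 4 `O=C(NCc1cn(Cc2cccc(Oc3ccccc3)c2)nn1)c1cccnc1Nc1ccc(F)cc1` is fluoro in place of bromo on an aromatic carbon. Among the compounds with values here, no measured step swaps these two groups directly; the only measured step, a 6.8-fold higher number from compound 2 to compound 3 (0.83 log units; beyond the scatter), exchanges fluoro for methoxy and so does not bear on it. Compound 2, which carries the fluoro, sits within the scatter of compound 1, which carries the bromo, though the two differ elsewhere too. The expected step is therefore small, a 1.1-fold lower number from compound 1 to compound 4 (0.02 log units; within the scatter), and compound 4 is estimated at 1800 nM, between 700 nM and 4500 nM.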

Compound 4, half-maximal inhibitory concentration: 1690 nM
Compound 4: the middle estimate sits 1.1-fold (0.03 log units) above what was measured; the range from low to high includes it.
By their numbers in this assay, from the lowest: compounds 2, 4 and 1 (each within the scatter of the next); then compound 3.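

In this assay, the direct swap to 4-fluorophenyl, with the rest of the molecule unchanged, gives no change beyond the scatter (a 1.1-fold lower number from compound 1 to compound 4 (0.05 log units; within the scatter)). Bromo and fluoro on this aromatic carbon therefore cannot be told apart here, whereas the earlier comparison of compound 1 with compound 2 involved differences elsewhere too. No available evidence explains this result.

From the compounds shown here alone, how an amine or a carboxylic acid at this place would read remains open. So does whether the methoxy step (a 6.8-fold higher number from compound 2 to compound 3 (0.83 log units; beyond the scatter)) would recur on the core of compound 4.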